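Aryl group exchange on compound 2

A few compounds are considered here, and "the series" means these few. Any claim that something is new, unique, unknown or untested is made for them only; others in the source may bear on it.

Among the compounds with values here, in a functional assay on CRL2813 cells (Homo sapiens) for cytotoxicity, read by sulforhodamine B assay, with a stated time of 5 days (a lower number here means a stronger inhibitor, a higher number a weaker inhibitor), compound 1 (`O=C(Nc1ccc([N+](=O)[O-])cc1)N[C@H]1CC[C@H](Oc2ccc(F)cc2)CC1`) gives 2300 nM and compound 2 (`O=C(Nc1ccccc1F)N[C@H]1CC[C@H](Oc2ccc(F)cc2)CC1`) gives 17500 nM, the higher of the two numbers so far. Compound 3 (`O=C(Nc1cccc(I)c1)N[C@H]1CC[C@H](Oc2ccc(F)cc2)CC1`) is still unmeasured. It carries 3-iodophenyl in place of 2-fluorophenyl on an amide-type nitrogen. Within the data shown here, only one measured step bears on this place, a 7.6-fold higher number from compound 1 to compound 2 (0.88 log units; beyond the scatter), a modest change beyond the scatter that shows the group on this nitrogen can move the number. Among the measured compounds shown here, no measured compound carries iodine, so the direction is a weak call. Compound 2 at 17500 nM is the high end of the range seen, so a smaller step towards a lower number is expected. The estimate means a 2.9-fold lower number from compound 2 to compound 3 (0.46 log units; beyond the scatter). Compound 3 is expected at 6000 nM, with an estimated range from 2000 nM to 18000 nM.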

Compound 3, half-maximal inhibitory concentration: 5200 nM
For compound 3 the middle estimate is 1.2-fold (0.06 log units) above the measured one; the range from low to high includes it.
By their numbers in this assay, from the lowest: compound 1; then compound 3; then compound 2.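

In this assay, 3-iodophenyl on the amide-type nitrogen gives a 3.4-fold lower number from compound 2 to compound 3 (0.53 log units; beyond the scatter) and thus shows that a lower number at this position is not confined to the 4-nitrophenyl group of compound 1. The comparison with that group still shows a 2.3-fold higher number from compound 1 to compound 3 (0.35 log units; beyond the scatter) as its result, so the three aryl groups give three separate levels in this small set. No measurement shown here accounts for this order.

The 2-fluorophenyl and 3-iodophenyl groups differ in both the halogen and its ring position, so the two changes cannot be separated; 3-fluorophenyl or 2-iodophenyl would be needed to do so. From the compounds shown here alone, how an amine or a carboxylic acid on this phenyl ring would read in the same assay also remains open.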